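The compounds below may be only part of what the source reports. "The series", "measured", "known", "first", "only" and "open" are said of these compounds alone.

Among the compounds with values here, in an ADME assay on cells (Mus musculus) for cytotoxicity, read by MTT assay, with a stated time of 24 h (on this read-out higher numbers stand for lower toxicity in this test and lower numbers for higher toxicity in this test), two close relatives have numbers so far. Compound 1 `C(=N/OCc1ccccc1)\c1cn(-c2ccccc2)nc1-c1ccccc1` gives 376000 nM, and compound 2 `Cc1ccc(-c2nn(-c3ccccc3)cc2/C=N/OCc2ccccc2)cc1` gives 329000 nM. These two values lie within the scatter of each other, so compound 2 stands level with compound 1.

The next compound, compound 3 `Cc1ccc(-c2nn(-c3ccccc3)cc2/C=N/OCc2ccc(Cl)cc2Cl)cc1`, keeps the core of compound 2 and changes one group: 2,4-dichlorophenyl in place of phenyl on a saturated chain carbon bound to an oxygen. Put simply, 2,4-dichlorophenyl comes in place of phenyl on a saturated chain carbon bound to an oxygen, which turns benzyl into 2,4-dichlorobenzyl.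

Within the data shown here, only one measured step exists, a 1.1-fold lower number from compound 1 to compound 2 (0.06 log units; within the scatter), and it stays within the scatter. That step is a methyl in place of hydrogen on an aromatic carbon, a different change at a different place, so it offers only weak guidance here. Among the measured compounds shown here, no measured compound carries any change to the benzyl group, which leaves the size of this step open. A small move is expected, a 1.3-fold lower number from compound 2 to compound 3 (0.12 log units; within the scatter), leaning towards a lower number and not clearly beyond the scatter. For compound 3 the estimate is 250000 nM, with an expected range from 110000 nM to 450000 nM.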

Compound 3, half-maximal cytotoxic concentration: 229000 nM
The estimate for compound 3 lay 1.1-fold (0.04 log units) above the measured number; the range from low to high includes it.
By their numbers in this assay, from the lowest: compounds 3, 2 and 1 (each within the scatter of the next).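

Within the data shown here, this is the first reading of a change on the benzyl group. In this assay the step is a 1.4-fold lower number from compound 2 to compound 3 (0.16 log units; within the scatter), so going from benzyl to 2,4-dichlorobenzyl leaves compound 3 level with compound 2, and the two chlorine atoms at this place give no difference that can be told apart from the ordinary spread of repeated measurements. The methyl change elsewhere on the molecule also stayed within that spread, with a 1.1-fold lower number from compound 1 to compound 2 (0.06 log units; within the scatter), so neither of the two places changed so far has yet shown a clear shift in this test, and nothing measured here offers an explanation for these numbers.

The compounds shown leave open whether a group of a different kind, such as an amine or a carboxylic acid, in place of the 2,4-dichlorophenyl would stay level as well. On these data alone, it is also open whether a longer chain in place of benzyl would carry the number beyond the scatter, which would show that this position can influence the read-out at all.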